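Replacing the hydroxy group of compound 3

The compounds below may be only part of what the source reports. "The series", "measured", "known", "first", "only" and "open" are said of these compounds alone.

Measured in a functional assay on OVCAR-8 cells (Homo sapiens); on this read-out higher numbers stand for weaker inhibition of growth and lower numbers for stronger inhibition of growth:
- compound 1 `O=S(=O)(/C=C/c1ccc(C(F)(F)F)cc1F)Cc1ccc(Nc2ncnc3ccccc23)cc1`: 100000 nM
- compound 2 `O=S(=O)(/C=C/c1ccc(Cl)cc1)Cc1ccc(Nc2ncnc3ccc(Br)cc23)cc1`: 3000 nM
- compound 3 `O=S(=O)(/C=C/c1ccc(O)cc1)Cc1ccc(Nc2ncnc3ccc(Br)cc23)cc1`: > 100000 nM (a limit)

Compound 3 stands only at a limit in this assay, and its > 100000 nM is not a number. That is the limit of > 100000 nM in this assay, at which 1 of the 3 values shown sits.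

The next structure is compound 4 `O=S(=O)(/C=C/c1ccc(C(F)(F)F)cc1F)Cc1ccc(Nc2ncnc3ccc(Br)cc23)cc1`. The change is 2-fluoro-4-(trifluoromethyl)phenyl in place of 4-hydroxyphenyl on a double-bonded chain carbon bound to a double-bonded chain carbon.

Among the measured compounds shown here, one measured step bears on this change. It is an at least 33-fold higher number from compound 2 to compound 3 (1.52 log units; beyond the scatter), a large step that came with hydroxy in place of chloro on an aromatic carbon. Compound 4 also loses the hydroxy, so a large step in the opposite direction is expected, towards stronger inhibition of growth. The closest guide is compound 2 at 3000 nM, although its chloro differs from the group that enters here. A note of caution comes from compound 1, which carries the entering group on its own core and gives 100000 nM. The estimated change is an at least 16-fold lower number from compound 3 to compound 4 (1.22 log units; beyond the scatter). For compound 4 the expected value is 6000 nM, with an estimated range of 1500 nM to 30000 nM.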

Compound 4, concentration for 50% growth inhibition: 15000 nM
Estimate against measurement, compound 4: 2.5-fold (0.40 log units) below; measured number inside the range.
By their numbers in this assay, from the lowest: compound 2; then compound 4; then compound 1.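

In this assay the 2-fluoro-4-(trifluoromethyl)phenyl group, in place of 4-hydroxyphenyl on the shared core, gives an at least 6.6-fold lower number from compound 3 to compound 4 (0.82 log units; beyond the scatter) and brings the read-out back to a measured number, but the size of this step is only a lower bound, as compound 3 stands at a limit: the limit of > 100000 nM in this assay, at which 1 of the 4 values shown sits. The group that enters counts as well as the hydroxy that leaves, for the exchange with 4-chlorophenyl shows a 5.0-fold higher number from compound 2 to compound 4 (0.70 log units; beyond the scatter) and so the two hydroxy-free groups are not equivalent at this position. Among the compounds shown here, the bromo also counts, a point the earlier compounds could not settle on their own: with the same 2-fluoro-4-(trifluoromethyl)phenyl group on both sides, bromo in place of hydrogen on an aromatic carbon gives a 6.7-fold lower number from compound 1 to compound 4 (0.82 log units; beyond the scatter) as a modest gain in growth inhibition.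

The compounds shown leave open whether the bromo gives a step of similar size when 4-chlorophenyl is the group on the double-bonded chain carbon. Also open, on these data alone, is how an amine or a methoxy group in place of the hydroxy would stand, and so whether the weak result of compound 3 is peculiar to the hydroxy.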